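The source may report more compounds than this note shows. Statements on the series, on what has been measured and on what is new or still open speak of the compounds shown alone.

Of the compounds shown here, three built on one shared core have been tested in an assay on isolated protein for inhibition of DNA topoisomerase 1 (Homo sapiens), with a stated time of 30 min, tested at 100 uM; a higher number here means more inhibition at the concentration tested (going by the name of the read-out), a lower number less inhibition. Compound 1 `Cc1ccsc1-c1cc(-c2ccco2)cc(-c2ccc(Cl)cc2)n1` gives 1% in this assay. Compound 2 `Cc1ccsc1-c1cc(-c2ccoc2)cc(-c2ccco2)n1` gives 5.4%. Compound 3 `Cc1ccccc1-c1cc(-c2ccoc2)cc(-c2ccc(Cl)s2)n1` gives 4.6%. All three numbers are small, and the gaps among them fall within the usual scatter of repeated measurements, so compound 3 cannot be set apart from either companion on these numbers: it sits among three compounds that barely inhibit the enzyme at the tested concentration.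

The next compound, compound 4 `Clc1ccc(-c2cc(-c3ccoc3)cc(-c3cccnc3)n2)s1`, keeps the core of compound 3 and differs in a single place: pyridin-3-yl in place of 2-methylphenyl on an aromatic carbon. For the measured compounds named here, no measured pair differing in only one place exists here, so no measured step can guide the expectation directly. With every measured number close to the floor of the read-out, the change is expected to leave the number near that floor. The expected step is a number 0.6 percentage points lower from compound 3 to compound 4 (within the scatter), nothing beyond the scatter. Compound 4 is therefore estimated at 4%, with a likely range from 0% to 15%.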

Compound 4, a percentage reported as inhibition, at one concentration (the size of the read-out at that concentration, not a potency): 2%
Compound 4: the middle estimate sits 2 percentage points above what was measured; measured number inside the range.
By their numbers in this assay, from the lowest: compounds 1, 4, 3 and 2 (each within the scatter of the next).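

For the compounds shown here, replacing 2-methylphenyl with pyridin-3-yl on the aromatic carbon next to the ring nitrogen gives, in this assay, a number 2.6 percentage points lower from compound 3 to compound 4 (within the scatter), the first reading of a change at a single place. At this position, then, exchanging a carbon-only ring for one with a ring nitrogen and a hydrogen-bond acceptor does not separate the two compounds, and both stay close to the floor of the read-out. No measurement at hand explains this result.

The compounds shown leave open whether a different kind of group at this place, such as an amine, a carboxylic acid or a longer chain, would move the number clear of the scatter. They also leave open whether changing the furan-3-yl or 5-chlorothiophen-2-yl group alone would do so.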